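This account rests on a few compounds, and the source may have more. Where it says the series, first, only, none or still open, it means among the compounds named here.

In a functional assay on HL-60 cells (Homo sapiens) for cytotoxicity, read by luminescence and CellTiter-Glo, with a stated time of 3 days (on this read-out lower numbers stand for stronger inhibition and higher numbers for weaker inhibition), compound 1 (`COc1ccc(O)c(C(=O)Nc2ccc(C#N)cc2)c1`) gives > 10000 nM, which is a limit of the assay and not a number. Compound 2 (`COc1cccc(C(=O)Nc2ccc(C#N)cc2)c1O`) gives > 10000 nM, also a limit. Compound 3 (`Cc1cccc(C(=O)Nc2ccc(C#N)cc2)c1O`) gives > 10000 nM, again a limit. Every reading so far is therefore of one kind: the limit of > 10000 nM in this assay, at which 3 of the 3 values shown sit.

Compound 4 (`N#Cc1ccc(NC(=O)c2ccccc2O)cc1`) has hydrogen in place of methyl on an aromatic carbon, ortho to a hydroxy group: hydrogen in place of methyl on an aromatic carbon. For the measured compounds named here, the one measured step that bears on this change is methyl in place of methoxy on that same aromatic carbon, a step that the two limits leave unreadable from compound 2 to compound 3. Going by the values given here, it gives no size to carry over, and no compound in the set offers a number to anchor a direction. The forecast must start from compound 3 at > 10000 nM, a limit, and no clear move is expected in this assay.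

The expected change is a step that the limit leaves unreadable from compound 3 to compound 4, and no shift beyond the scatter is estimated. For compound 4 the estimated value is 12000 nM, with an expected range from 4000 nM to 30000 nM, and the assay is expected most likely to report only a limit again.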

Compound 4, half-maximal inhibitory concentration: 4620 nM
Compound 4: the middle estimate sits 2.6-fold (0.41 log units) above what was measured, within the range that was stated.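

For the compounds shown here, with hydrogen on the aromatic carbon ortho to a hydroxy group, this assay gives a readable value for the first time, and replacing methyl there amounts to an at least 2.1-fold lower number from compound 3 to compound 4 (0.33 log units; beyond the scatter). Replacing methoxy on that same carbon gives an at least 2.1-fold lower number from compound 2 to compound 4 (0.33 log units; beyond the scatter), while removing the methoxy group from a different aromatic carbon gives an at least 2.1-fold lower number from compound 1 to compound 4 (0.33 log units; beyond the scatter), so the unsubstituted ring of compound 4 compares favourably with all three substituted compounds shown. Compound 4 is also the only compound shown that comes off the assay's limit, which sets it apart from a series that until then offered no number at all: the limit of > 10000 nM in this assay, at which 3 of the 4 values shown sit.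

On these data alone, the real size of these steps stays open, as each starts from a limit and not a number, and the earlier step between the methoxy and methyl compounds cannot be read either. Also open, as far as these compounds go, is whether the gain belongs to hydrogen alone or would survive a fluorine atom or an amine on that carbon, and whether the hydroxy group and the nitrile can give way to a carboxylic acid or an amine without returning the compound to the limit.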